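The source may hold more compounds than are shown below. What is called first, only, known or untested is meant among the compounds shown, and "the series" means these compounds.

Measured so far:
- Compound 1 `Cc1nc(N2CCN(C)CC2)c2nc(-c3ccccc3Cl)n(CCO)c2n1`: 13%
- Compound 2 `CCN1CCN(c2nc(C)nc3c2nc(-c2ccccc2Cl)n3CCOC)CC1`: 31%
- Compound 3 `COCCn1c(-c2ccccc2Cl)nc2c(N3CCN(C(C)=O)CC3)nc(C)nc21`: 35%

In an ADME assay (liver) for metabolic stability, with Liver microsome (Homo sapiens) as the target, read by LC-MS, using microsomes, with a stated time of 30 min, tested at 4 uM (a lower number here means that less of the compound is left, a higher number that more of the compound is left), compound 3 gives 35%. That is within the scatter of compound 2 at 31%, while compound 1 at 13% lies clearly lower.

The next compound to be tested is compound 4 `COCCn1c(-c2ccccc2Cl)nc2c(N3CCN4C(=O)CCC4C3)nc(C)nc21`. It differs from compound 3 in one place: a group of 10 heavy atoms (7 carbon, 2 nitrogen, 1 oxygen; one five-membered non-aromatic ring with 1 hetero atom, one six-membered non-aromatic ring with 2 hetero atoms) in place of a group of 9 heavy atoms (6 carbon, 2 nitrogen, 1 oxygen; one six-membered non-aromatic ring with 2 hetero atoms), on an aromatic carbon. The 4-acetylpiperazin-1-yl group leaves, and the group that enters carries an additional five-membered non-aromatic ring.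

Going by the values given here, only one measured step changes this same part of the molecule: a number 4 percentage points higher from compound 2 to compound 3 (within the scatter). It lies within the scatter and puts acetyl in place of ethyl on an amine nitrogen in a ring. Among the compounds with values here, compound 1 differs from compound 3 in more than one place, so it offers no clean single step. Within the data shown here, no measured step adds a five-membered non-aromatic ring, which leaves the comparison with compound 4 weak.

Among the measured compounds shown here, with that one small step as the only guide, no clear change in either direction is expected in this assay. The expected step is a number 2 percentage points lower from compound 3 to compound 4 (within the scatter), which would stay within the scatter. For compound 4 the estimated value is 33%, with an expected range of 18% to 50%.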

Compound 4, percent of the compound remaining: 32%
The estimate for compound 4 lay 1 percentage points above the measured number; measured number inside the range.
By their numbers in this assay, from the lowest: compound 1; then compounds 2, 4 and 3 (each within the scatter of the next).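

Compound 4 brings an additional five-membered non-aromatic ring to the aromatic carbon next to the ring nitrogen, and in this assay this gives a number 3 percentage points lower from compound 3 to compound 4 (within the scatter). Set against the ethyl group on the ring amine nitrogen of compound 2, the same new group gives a number 1 percentage points higher from compound 2 to compound 4 (within the scatter), and the earlier exchange of ethyl for acetyl gave a number 4 percentage points higher from compound 2 to compound 3 (within the scatter), so all three steps among these compounds stay within the scatter. At this position, then, the ethyl group, the acetyl group and the added fused ring cannot be told apart in this read-out, although nothing measured here offers a reason for that.

The compounds shown leave open whether a different kind of group on this aromatic carbon, such as a morpholine ring, a small open-chain amine or a piperazine bearing a carboxylic acid, would move the percentage remaining beyond the scatter. Going by these compounds, the methoxyethyl chain and the chlorophenyl group are also the same in compounds 2, 3 and 4, so the effect of a longer chain or a different aromatic ring at those places stays open as well.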